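The source may report more compounds than this note shows. Statements on the series, on what has been measured and on what is new or still open speak of the compounds shown alone.

Compound 1 `Cc1cc(C(=O)O)ccc1OCCCCOc1ccc(C(=O)CC(C)C)c(O)c1C`, compound 2 `Cc1c(OCCCCOc2ccc(C(=O)C(C)C)c(O)c2C)cccc1C(=O)O` and compound 3 `CCCC(=O)c1ccc(OCCCCOc2ccc(C(=O)O)cc2C)c(C)c1O` share a long linker with a carboxylic acid on one ring and a ketone on the other, and were tested in an assay on HEK293 cells for positive allosteric modulation of metabotropic glutamate receptor 3 (Rattus norvegicus), read by thallium flux, with a stated time of 2.5 min; on this read-out lower numbers stand for smaller maximal responses and higher numbers for larger maximal responses. In this assay compound 1 gives 42.1%, compound 3 gives 40.5% and compound 2 gives 27.1%. Compound 3 differs from compound 1 only by hydrogen in place of methyl on a saturated chain carbon bound to two saturated chain carbons, and this made a step of a number 1.6 percentage points lower from compound 1 to compound 3 (within the scatter). The difference between the cores of compound 1 and compound 2 is not broken down here. Compound 4 `CCC(=O)c1ccc(OCCCCOc2cccc(C(=O)O)c2C)c(C)c1O` has not yet been measured; it differs from compound 2 by hydrogen in place of methyl on a saturated chain carbon bound to a carbonyl carbon and a saturated chain carbon. This is the same kind of change as before, but here the carbon carrying it is bound to a carbonyl carbon and a saturated chain carbon rather than to two saturated chain carbons. Because the earlier change gave only a number 1.6 percentage points lower from compound 1 to compound 3 (within the scatter), the step is expected to be about a number 0.1 percentage points lower from compound 2 to compound 4 (within the scatter). Compound 4 is therefore estimated at 27%, most likely between 15% and 40%.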

Compound 4, largest response reached (reported as percent of maximum), in percent of the reference or control that the assay uses: 16.3%
The estimate for compound 4 lay 10.7 percentage points above the measured number, and the stated range covers the measured number.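

In this assay, the change of isopropyl to ethyl gave a number 10.8 percentage points lower from compound 2 to compound 4 (beyond the scatter), a modest step. Set beside the earlier methyl-to-hydrogen change, it does not stand apart by more than repeated measurements would allow: the same change on two cores in this assay, a number 1.6 percentage points lower (within the scatter) from compound 1 to compound 3 and a number 10.8 percentage points lower (beyond the scatter) from compound 2 to compound 4, 9.2 percentage points apart, within the scatter of two such steps. This gives no sign that the change behaves differently on the two cores, but two pairs cannot show that it carries over reliably, and the carbon carrying the change is not the same kind in each pair.

The compounds shown leave open what a cyclopropyl group or a longer chain at this place would do to the maximal response. As far as these compounds go, whether an amine in place of the carboxylic acid would alter the step also remains open.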